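This account rests on a few compounds, and the source may have more. Where it says the series, first, only, none or still open, it means among the compounds named here.

Measured in an ADME assay on Vero cells (Chlorocebus sabaeus) for cytotoxicity; a lower number here means a stronger inhibitor, a higher number a weaker inhibitor:
Compound 1 `Nc1ccn([C@@H]2S[C@H](CO)C=C2F)c(=O)n1`: > 100000 nM
Compound 2 `Cc1cn([C@@H]2S[C@H](CO)C=C2F)c(=O)nc1O`: 53000 nM

Among the measured compounds shown here, only two readings exist so far in this assay, and just one of them is an actual number. Compound 2 holds that number, 53000 nM, so it has no second measured value to be ranked against. Compound 1 returned only a limit, > 100000 nM. For the measured compounds named here, no step between measured compounds is available to serve as a guide.

The next compound to be measured is compound 3 `O=c1nc(O)ccn1[C@@H]1S[C@H](CO)C=C1F`. It differs from compound 2 by one small change: hydrogen in place of methyl on an aromatic carbon. Hydrogen stands in place of methyl on an aromatic carbon, ortho to a hydroxy group, and the rest of the structure is shared.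

With nothing measured for such a change, the expectation rests on the two readings alone, and it is a cautious one. A modest move toward weaker inhibition, not far beyond the scatter, is expected: a 1.4-fold higher number from compound 2 to compound 3 (0.15 log units; within the scatter). Compound 3 may also return only a limit. For compound 3 the estimated value is 75000 nM, with an expected range from 30000 nM to 180000 nM.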

Compound 3, half-maximal inhibitory concentration: > 100000 nM
Compound 3 was reported as a limit; the forecaster's own chance of this, stated with the estimate: 45%; middle value at least 1.3-fold (0.12 log units) away from the limit.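

In this assay, among the compounds shown here, compound 2 remains the only compound with an actual number, 53000 nM, and the methyl on the aromatic carbon, ortho to a hydroxy group, is the one place where it differs from compound 3. Hydrogen in place of that methyl gives an at least 1.8-fold higher number from compound 2 to compound 3 (0.27 log units; that floor lies within the scatter), so the result shows only a floor for this change and does not establish a shift beyond the scatter. The true size of the step stays hidden because compound 3 returned only a limit, the same ceiling that bounds most of this small set: the limit of > 100000 nM in this assay, at which 2 of the 3 values shown sit.

The step for hydroxy in place of amino on the aromatic carbon cannot be read, since compound 1 and compound 3 are both reported as limits. Also open, as far as these compounds go, is whether the methyl itself matters or whether another group on that aromatic carbon, such as an ethyl, a chlorine atom or a trifluoromethyl, would give a measurable number in this assay.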